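A few compounds are considered here, and "the series" means these few. Any claim that something is new, unique, unknown or untested is made for them only; others in the source may bear on it.

Compound 1 `O=[N+]([O-])c1ccc(-c2nnc(-c3cccnc3)n2Nc2nc3ccc(F)cc3s2)cc1` opens the set. In an ADME assay on MT4 cells (Homo sapiens) for cytotoxicity, read by MTT assay, with a stated time of 5 days (a higher number here means that more compound is tolerated, a lower number that less compound is tolerated), compound 1 reaches only a limit of the assay, >= 108 ug/mL. Compound 2 `Cc1cccc2sc(Nn3c(-c4ccc([N+](=O)[O-])cc4)nnc3-c3cccnc3)nc12` rests on a different core, the difference being (4-methyl-1,3-benzothiazol-2-yl in place of 6-fluoro-1,3-benzothiazol-2-yl on a nitrogen on an aromatic ring), and in this assay compound 2 gives 13.5 ug/mL, a step of an at least 8.0-fold lower number from compound 1 to compound 2 (0.90 log units; beyond the scatter). Compound 3 `Fc1ccc2nc(Nn3c(-c4ccc(Cl)cc4)nnc3-c3cccnc3)sc2c1` keeps the core of compound 1 but carries chloro in place of nitro on an aromatic carbon; in this assay compound 3 gives 92.9 ug/mL. On these data alone, that step is an at least 1.1-fold lower number from compound 1 to compound 3 (0.06 log units; that floor lies within the scatter), and its true size stays open because of the limit of >= 108 ug/mL in this assay, at which 1 of the 3 values shown sits. Compound 4 `Cc1cccc2sc(Nn3c(-c4ccc(Cl)cc4)nnc3-c3cccnc3)nc12` applies the same change to compound 2, (chloro in place of nitro on an aromatic carbon), at a place described in identical words. The step expected from compound 2 to compound 4 is a 1.1-fold lower number from compound 2 to compound 4 (0.05 log units; within the scatter), resting on compound 3 having shown an at least 1.1-fold lower number from compound 1 to compound 3 (0.06 log units; that floor lies within the scatter). Compound 4 is therefore estimated at 12 ug/mL, within a range from 5 ug/mL to 35 ug/mL.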

Compound 4, half-maximal cytotoxic concentration: 36.5 ug/mL
For compound 4 the middle estimate is 3.0-fold (0.48 log units) below the measured one; the whole stated range lies below it.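

Replacing nitro with chloro on the core of compound 2 gives a 2.7-fold higher number from compound 2 to compound 4 (0.43 log units; beyond the scatter) in this assay, so the change did not carry over with the same effect from the core of compound 1: the same change on two cores in this assay, an at least 1.1-fold lower number (0.06 log units; that floor lies within the scatter) from compound 1 to compound 3 and a 2.7-fold higher number (0.43 log units; beyond the scatter) from compound 2 to compound 4, at least 3.1-fold (0.49 log units) apart, beyond the scatter of two such steps. On these data alone, the exact size of the step on the core of compound 1 stays unknown, since compound 1 reaches only a limit of the assay: the limit of >= 108 ug/mL in this assay, at which 1 of the 4 values shown sits. Two cores show that this step need not transfer unchanged, but they do not show why the cores differ or predict the step on any other core.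

The compounds shown leave open what the same change would do on a third core. They also leave open how an amine or a carboxylic acid on that aromatic carbon would behave in this assay.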